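Varying the Aryl Ketone on a Triazole Core

The source may report more compounds than this note shows. Statements on the series, on what has been measured and on what is new or still open speak of the compounds shown alone.

Compound 1 `COc1cc(-c2nnc3n2NC(c2ccco2)C(C(=O)c2ccc(Br)cc2)S3)cc(OC)c1OC` was tested in a functional assay on PC-3 cells (Homo sapiens) for cytotoxicity, read by MTT assay, with a stated time of 48 h (a higher number here means a weaker inhibitor, a lower number a stronger inhibitor), where compound 1 gives 36400 nM. Of the three numbers in hand this is the second highest; its nearest neighbour is compound 2 `COc1cc(-c2nnc3n2NC(c2ccco2)C(C(=O)c2ccc(F)cc2)S3)cc(OC)c1OC`, which gives 27700 nM, and the furthest is compound 3 `COc1cc(-c2nnc3n2NC(c2ccco2)C(C(=O)C2CC2)S3)cc(OC)c1OC`, which gives 95200 nM. The step of a 1.3-fold lower number from compound 1 to compound 2 (0.12 log units; within the scatter) stays within the scatter, whereas a 2.6-fold higher number from compound 1 to compound 3 (0.42 log units; beyond the scatter) and a 3.4-fold higher number from compound 2 to compound 3 (0.54 log units; beyond the scatter) lie beyond it.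

The unmeasured compound 4 `COc1cccc(C(=O)C2Sc3nnc(-c4cc(OC)c(OC)c(OC)c4)n3NC2c2ccco2)c1` differs from compound 1 in a single place: 3-methoxyphenyl in place of 4-bromophenyl on a carbonyl carbon

Going by the values given here, the steps that bear on this change are those touching the group on the carbonyl carbon. Putting fluoro in place of bromo on an aromatic carbon, a 1.3-fold lower number from compound 1 to compound 2 (0.12 log units; within the scatter), left the number within the scatter, while putting cyclopropyl in place of 4-bromophenyl on a carbonyl carbon, a 2.6-fold higher number from compound 1 to compound 3 (0.42 log units; beyond the scatter), raised it modestly. Compound 4 retains one six-membered aromatic ring of carbon only on the carbonyl carbon, so the change resembles the first of these steps more than the second. Compound 4 is therefore expected to show a step of a 1.0-fold lower number from compound 1 to compound 4 (0.02 log units; within the scatter) that remains within the scatter. Among the compounds with values here, no measured compound carries 3-methoxyphenyl at this place, so the expectation rests on the two aryl ketones alone. Compound 4 is estimated at 35000 nM, with a range from 15000 nM to 85000 nM.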

Compound 4, half-maximal inhibitory concentration: 84600 nM
The estimate for compound 4 lay 2.4-fold (0.38 log units) below the measured number, and the stated range covers the measured number.
By their numbers in this assay, from the lowest: compounds 2 and 1 (each within the scatter of the next); then compounds 4 and 3 (each within the scatter of the next).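

In this assay, keeping an aromatic ring on the carbonyl carbon does not by itself keep the number close to those of the halogen-bearing ketones: 3-methoxyphenyl in place of 4-bromophenyl gives a 2.3-fold higher number from compound 1 to compound 4 (0.37 log units; beyond the scatter), and in place of 4-fluorophenyl it gives a 3.1-fold higher number from compound 2 to compound 4 (0.48 log units; beyond the scatter). Against cyclopropyl, the same group gives a 1.1-fold lower number from compound 3 to compound 4 (0.05 log units; within the scatter), so the four compounds divide into the 4-bromophenyl and 4-fluorophenyl ketones on one side and the 3-methoxyphenyl and cyclopropyl ketones on the other, and compound 4 goes against any split into aryl and non-aryl ketones. Nothing available explains why 3-methoxyphenyl falls with cyclopropyl here.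

The change from 4-bromophenyl to 3-methoxyphenyl alters both the substituent and where it stands on the ring, and the compounds shown do not separate these two differences. From the compounds shown here alone, it also remains open whether a plain phenyl, a phenyl carrying an amine or a carboxylic acid, or a longer alkyl chain on the carbonyl carbon would fall with compound 1 and compound 2 or with compound 3 and compound 4.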